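Replacing the pyrrole arm of compound 2 with a thiazole

The source may report more compounds than this note shows. Statements on the series, on what has been measured and on what is new or still open speak of the compounds shown alone.

Compound 2 `CCN(Cc1cccn1C)C(=O)COc1ccc(C)cc1` is the weakest of the three compounds measured in an assay on HEK293 cells for agonist activity at transient receptor potential cation channel subfamily M member 8 (Homo sapiens), read by fluorescence and calcium flux, with a stated time of 15 min; a higher number here means that more compound is needed for the effect, a lower number that less compound is needed: compound 2 gives 21300 nM. Its nearest neighbour on the numbers is compound 3 `CCN(Cc1cccs1)C(=O)c1cc2cc(C)ccc2[nH]1`, which in this assay gives 2010 nM, and the furthest is compound 1 `CCN(Cc1cccs1)C(=O)C(C)Oc1ccc(C)cc1`, which in this assay gives 889 nM; both gaps lie beyond the scatter of the method. Compounds 1 and 3 differ from compound 2 in more than one place, so no single change can be held responsible for the gap.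

The unmeasured compound 4 `CCN(Cc1nccs1)C(=O)COc1ccc(C)cc1` keeps the rest of compound 2 and alters only the group on the saturated chain carbon bound to the amide-type nitrogen: 1,3-thiazol-2-yl in place of 1-methyl-1H-pyrrol-2-yl on a saturated chain carbon bound to an amide-type nitrogen. The entering 1,3-thiazol-2-yl is smaller by one heavy atom and carries one more hydrogen-bond acceptor than the leaving 1-methyl-1H-pyrrol-2-yl, and the methyl on the ring nitrogen is gone.

Going by the values given here, with no measured pair isolating this change, the expectation rests only on compound 2 standing far above compounds 1 and 3. Compound 4 is expected to move in this assay toward the other two, by a step of a 6.1-fold lower number from compound 2 to compound 4 (0.78 log units; beyond the scatter) that exceeds the scatter. The estimate for compound 4 in this assay is 3500 nM, with a likely range from 900 nM to 14000 nM.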

Compound 4, half-maximal effective concentration: 3060 nM
For compound 4 the middle estimate is 1.1-fold (0.06 log units) above the measured one; the range from low to high includes it.
By their numbers in this assay, from the lowest: compound 1; then compounds 3 and 4 (each within the scatter of the next); then compound 2.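

In this assay, compound 2 and compound 4 form the only pair among these compounds that differs in one place, so the effect of this change can now be read directly: 1,3-thiazol-2-yl in place of 1-methyl-1H-pyrrol-2-yl on a saturated chain carbon bound to an amide-type nitrogen gives a 7.0-fold lower number from compound 2 to compound 4 (0.84 log units; beyond the scatter) in this pair. The group at this position can therefore by itself shift the number beyond the scatter, which compounds 1 and 3 could not show, as each differs from compound 2 in more than one place. No measurement at hand explains the step.

The swap alters the hetero atoms of the ring and removes the methyl on the ring nitrogen in one move, so the compounds shown leave open which of these differences carries the step; a 1-methyl-1H-imidazol-2-yl group at the same place would bear on that question. Also open, on these data alone, is how a six-membered aromatic group such as phenyl or pyridin-2-yl would fare on this saturated chain carbon.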